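Methoxy to methyl on two related cores: cytotoxicity outlook

The source may report more compounds than this note shows. Statements on the series, on what has been measured and on what is new or still open speak of the compounds shown alone.

Compound 1 `COC(=O)[C@@H]1COC(/C=C/c2ccc(OC)cc2)=N1` gives 20.9% in an ADME assay on Vero cells (Chlorocebus sabaeus) for cytotoxicity, read by WST assay, tested at 100 ug/mL; on this read-out higher numbers stand for a weaker effect at the one concentration tested and lower numbers for a stronger effect.
Compound 2 `COC(=O)[C@@H]1COC(/C=C/c2ccc(C)cc2)=N1` gives 17% in this assay.
Compound 3 `COC(=O)c1coc(/C=C/c2ccc(OC)cc2)n1` gives 96.8% in this assay.

Compound 1 and compound 2 share one core and differ only by methyl in place of methoxy on an aromatic carbon. That change made a step of a number 3.9 percentage points lower from compound 1 to compound 2 (within the scatter), so the two values cannot be told apart on this read-out. Compound 3 carries a different core; how the two cores differ is not broken down here. Its value stands highest of the three measured numbers, beyond the scatter from compound 1 and from compound 2.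

Compound 4 `COC(=O)c1coc(/C=C/c2ccc(C)cc2)n1` has not yet been measured. It differs from compound 3 by methyl in place of methoxy on an aromatic carbon, which is the same change already seen between compound 1 and compound 2, made at the same place on the six-membered ring. Among the compounds shown, this change occurs twice in all. Within the data shown here, the only measured instance of it, from compound 1 to compound 2, moved the read-out by an amount within the scatter, and that is the sole basis for any expectation here; whether a change behaves alike on two different cores cannot be checked from these data.

On that basis, the step from compound 3 to compound 4 in this assay is expected to be a number 3.8 percentage points lower from compound 3 to compound 4 (within the scatter), small beside the earlier one. Compound 4 is therefore estimated to give 93%, with a likely range from 78% to 102%, leaving it close to compound 3.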

Compound 4, a percentage reported as activity, at one concentration (the size of the read-out at that concentration, not a potency): 100%
Estimate against measurement, compound 4: 7 percentage points below; the range from low to high includes it.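

On the second core, methyl in place of methoxy on an aromatic carbon gave a number 3.2 percentage points higher from compound 3 to compound 4 (within the scatter) in this assay. Set beside the same swap on the first core, this step shows that the change carried from one core to the other with no difference that can be told apart from ordinary repeat variation, since neither step is large and the two do not differ: the same change on two cores in this assay, a number 3.9 percentage points lower (within the scatter) from compound 1 to compound 2 and a number 3.2 percentage points higher (within the scatter) from compound 3 to compound 4, 7.1 percentage points apart, within the scatter of two such steps. Among these compounds, this is a modest finding, resting on two pairs of compounds and one place on the six-membered ring, and it shows only that this swap left the read-out about where it was on both cores, not that other changes would transfer in the same way or that a change with a large effect on one core would have the same effect on the other.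

The compounds shown carry only methoxy or methyl at this place, para to a large group, so it remains open what an amine, a carboxylic acid or a longer chain there would do to the read-out. Going by these compounds, it also remains open whether any such group would behave alike on the two cores, which only matched pairs on both cores could answer.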